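Isopropyl to 3-chlorophenyl: an expected half-life for compound 3

The compounds below may be only part of what the source reports. "The series", "measured", "known", "first", "only" and "open" are said of these compounds alone.

Compound 1 `CC(C)C(NC(=O)c1ccc(C(=N)N)cc1)C(C)(C)C(=O)N1CCC(CC(=O)O)CC1` has been measured in an in vivo ADME assay on the whole organism (Cavia porcellus) (a higher number here means that the compound lasts longer, a lower number that the compound disappears faster), where compound 1 gives 0.8 h. For the measured compounds named here, its only companion is compound 2 `CC(C)CC(NC(=O)c1ccc(C(=N)N)cc1)C(C)(C)C(=O)N1CCC(CC(=O)O)CC1`, which in this assay gives 0.917 h; the step of a 1.1-fold higher number from compound 1 to compound 2 (0.06 log units; within the scatter) lies within the scatter, so the two numbers cannot be told apart. Compound 3 `CC(C)(C(=O)N1CCC(CC(=O)O)CC1)C(NC(=O)c1ccc(C(=N)N)cc1)c1cccc(Cl)c1` differs from compound 1 in a single place: 3-chlorophenyl in place of isopropyl on a saturated chain carbon bound to an amide-type nitrogen and a saturated chain carbon. Going by the values given here, the one measured step at that place, a 1.1-fold higher number from compound 1 to compound 2 (0.06 log units; within the scatter), exchanged one saturated chain for another and left the half-life where it was; it does not cover the entry of an aromatic ring carrying chlorine, so it bears on the present change only loosely. Among the compounds with values here, with no step of comparable kind available, compound 3 is expected to stay near compound 1, and the step of a 1.3-fold higher number from compound 1 to compound 3 (0.10 log units; within the scatter) is estimated to be small, though the allowance for the new ring must be wide. Compound 3 is therefore estimated at 1 h, within a range from 0.5 h to 2.2 h.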

Compound 3, half-life: 2.5 h
The estimate for compound 3 lay 2.5-fold (0.40 log units) below the measured number, and the stated range ends below it.
By their numbers in this assay, from the lowest: compounds 1 and 2 (each within the scatter of the next); then compound 3.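

In this assay, the position on a saturated chain carbon bound to an amide-type nitrogen and a saturated chain carbon now proves able to shift the half-life, which the exchange of one saturated chain for another (isobutyl for isopropyl) had not shown. The 3-chlorophenyl group gives a gain over both saturated groups, with isopropyl as the starting point (a 3.1-fold higher number from compound 1 to compound 3 (0.49 log units; beyond the scatter)) and with isobutyl as the starting point (a 2.7-fold higher number from compound 2 to compound 3 (0.44 log units; beyond the scatter)), so the result does not depend on which of these two chains it is compared with. No available evidence explains why this change lengthens the half-life.

The compounds shown leave open whether a plain phenyl or a cyclohexyl at this place would give a number like that of compound 3, and therefore whether the step goes with the ring, with its aromatic nature or with the chlorine it carries. Also open, going by these compounds, is whether a fluorine or a methoxy group in place of the chlorine would keep the gain, or whether a larger ring system would extend it further.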